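The compounds below may be only part of what the source reports. "The series", "measured", "known", "first", "only" and "open" are said of these compounds alone.

Measured so far, in a functional assay on PBMC cells (Homo sapiens) for inhibition, read by HTRF, with stated times of 15 min and 24 h; on this read-out higher numbers stand for weaker inhibition and lower numbers for stronger inhibition:

Compound 1 `O=C(Nc1ccc2c(c1)B(O)OC2)c1cccc(C(F)(F)F)c1` gives > 10000 nM, which is a limit of the assay and not a number.
Compound 2 `O=C(Nc1ccc2c(c1)B(O)OC2)c1ccc(C(F)(F)F)cc1` gives > 100000 nM, also a limit and not a number.
Compound 3 `O=C(Nc1ccc2c(c1)B(O)OC2)c1cccc(C(F)(F)F)c1F` gives > 100000 nM, again a limit and not a number.

All three share the same amide-linked core; the difference between the core of compound 1 and the core of compound 2 is not broken down here. Compound 3 arises from compound 1 by the change (fluoro in place of hydrogen on an aromatic carbon), and the resulting step that the two limits leave unreadable from compound 1 to compound 3 cannot be sized, since both values are limits, as the limit of > 10000 nM in this assay, at which 1 of the 3 values shown sits, and the limit of > 100000 nM in this assay, at which 2 of the 3 values shown sit, show.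

Compound 4 `O=C(Nc1ccc2c(c1)B(O)OC2)c1ccc(C(F)(F)F)cc1F` has not been measured. It arises from compound 2 by the change (fluoro in place of hydrogen on an aromatic carbon). This is the same kind of change as that from compound 1 to compound 3, but not the same: there the entering fluoro sits ortho to the trifluoromethyl group, here it sits meta to it.

Since compound 2 already sits at a limit, the step of a number no higher from compound 2 to compound 4 (the limit leaves the size open) is expected to stay unreadable. Compound 4 is therefore expected to give about 100000 nM in this assay, between 20000 nM and 300000 nM.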

Compound 4, half-maximal inhibitory concentration: > 100000 nM
Compound 4 gave a limit, no number (the forecaster's own chance of this, stated with the estimate: 85%); the middle value lies on the limit itself.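

In this assay, compound 2 and compound 4 both stand at a limit and not at a number, so no step between them can be read: the limit of > 100000 nM in this assay, at which 3 of the 4 values shown sit.

The compounds shown leave open whether fluoro in place of hydrogen on the aromatic carbon changes inhibition at all, and how strongly any of these compounds inhibits.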